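Methoxy removal on the carbonyl-side ring: compound 3

The compounds below may be only part of what the source reports. "The series", "measured", "known", "first", "only" and "open" are said of these compounds alone.

Measured so far:
compound 1 `COc1cc(-c2cc(/C=C/C(=O)c3ccc(N)cc3)[nH]n2)cc(OC)c1OC`: 98%
compound 2 `COc1ccc(C(=O)/C=C/c2cc(-c3cc(OC)c(OC)c(OC)c3)n[nH]2)cc1OC`: 97%

In a functional assay on NCI-H226 cells (Homo sapiens) for cytotoxicity, read by sulforhodamine B assay, with a stated time of 48 h, tested at 0.1 uM (a higher number here means a weaker effect of the compound at the concentration tested, a lower number a stronger effect), compound 1 gives 98%. In this assay compound 2 gives 97%. For the measured compounds named here, these are the only two numbers, and they lie within the scatter of each other, so neither can be set apart from the other; both sit close to no effect at the concentration tested.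

Going by the values given here, the single measured step, a number 1 percentage points lower from compound 1 to compound 2 (within the scatter), is the exchange of 3,4-dimethoxyphenyl in place of 4-aminophenyl on a carbonyl carbon: a substantial change on that ring without any shift beyond the scatter.

Compound 3 `COc1ccc(C(=O)/C=C/c2cc(-c3cc(OC)c(OC)c(OC)c3)n[nH]2)cc1` is not yet measured. It differs from compound 2 by hydrogen in place of methoxy on an aromatic carbon. The step from compound 1 to compound 2 bears on this only in that it touched the same ring and left the read-out flat. On that basis no step beyond the scatter is expected, and the step from compound 2 to compound 3 is estimated at no change at the digits printed from compound 2 to compound 3 (within the scatter). For compound 3 the expected value is 97%, with a range from 88% to 104%.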

Compound 3, a percentage reported as activity, at one concentration (the size of the read-out at that concentration, not a potency): 102%
Compound 3: middle estimate off by 5 percentage points, on the low side, and the stated range covers the measured number.
By their numbers in this assay, from the lowest: compounds 2, 1 and 3 (each within the scatter of the next).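

Removing one methoxy from the carbonyl-side ring, 3,4-dimethoxyphenyl to 4-methoxyphenyl, gives in this assay a number 5 percentage points higher from compound 2 to compound 3 (within the scatter), so at this position the loss of that group cannot be told apart from the scatter at the one concentration tested. The read-out also stays flat in the direct exchange on the same ring, a number 4 percentage points higher from compound 1 to compound 3 (within the scatter), which means that 4-aminophenyl, 3,4-dimethoxyphenyl and 4-methoxyphenyl on the carbonyl cannot be separated here, with compound 3 at 102% and all three close to no effect. A flat read-out this close to no effect says little about the role of this position, and nothing at hand offers an explanation for it.

Still open, going by these compounds, is whether a hydroxy group, a chlorine atom or a carboxylic acid on the carbonyl-side ring would move the read-out beyond the scatter, and whether a change on the other aromatic ring or in the linking chain would do so. Also open, on these data alone, is whether the three compounds would separate in a concentration-response measurement, since a single-concentration read-out near no effect gives no potency.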